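Naphthalen-1-yl replacing 4-formylphenyl on the shared core

The source may report more compounds than this note shows. Statements on the series, on what has been measured and on what is new or still open speak of the compounds shown alone.

Compound 3 `O=Cc1ccc(-c2cn3ccnc3c(-c3ccc4ncn(Cc5ccccc5)c4c3)n2)cc1` gives 46.9% in a functional assay on LOX IMVI cells (Homo sapiens) for inhibition, read by sulforhodamine B assay, with a stated time of 48 h, tested at 10 uM (a higher number here means more inhibition at the concentration tested (going by the name of the read-out), a lower number less inhibition), the highest of the three numbers recorded so far. Compound 2 `Cc1cccc(-c2cn3ccnc3c(-c3ccc4ncn(Cc5ccccc5)c4c3)n2)c1` gives 14.8% in this assay, and compound 1 `c1ccc2c(-c3cn4ccnc4c(-c4ccc5ncn(C6CCCCC6)c5c4)n3)cccc2c1` gives 7.43%. Going by the values given here, the only recorded step at this position of the core, a number 32.1 percentage points higher from compound 2 to compound 3 (beyond the scatter), was large. Compound 4 `c1ccc(Cn2cnc3ccc(-c4nc(-c5cccc6ccccc56)cn5ccnc45)cc32)cc1` undoes that exchange with a different group: naphthalen-1-yl in place of 4-formylphenyl on an aromatic carbon. Among the compounds with values here, no recorded step covers this change directly, but compound 1 already carries the naphthalen-1-yl group, and its value lies close to that of compound 2, both well below compound 3. A large drop, a number 34.9 percentage points lower from compound 3 to compound 4 (beyond the scatter), is therefore expected, returning to the level of those two compounds. Compound 4 is estimated at 12%, within 2% to 28%.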

Compound 4, a percentage reported as inhibition, at one concentration (the size of the read-out at that concentration, not a potency): 16.5%
Estimate against measurement, compound 4: 4.5 percentage points below, within the range that was stated.
By their numbers in this assay, from the lowest: compounds 1, 2 and 4 (each within the scatter of the next); then compound 3.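

At the aromatic carbon, this assay gives a number 30.4 percentage points lower from compound 3 to compound 4 (beyond the scatter) on leaving 4-formylphenyl but a number 1.7 percentage points higher from compound 2 to compound 4 (within the scatter) for naphthalen-1-yl against 3-methylphenyl, so among these three groups only 4-formylphenyl stands apart. At the aromatic nitrogen, the step gives a number 9.1 percentage points higher from compound 1 to compound 4 (within the scatter) for benzyl against cyclohexyl, so these two groups cannot be told apart with naphthalen-1-yl on the core. Nothing measured here accounts for the separate standing of 4-formylphenyl.
Open, going by these compounds, is whether a carboxylic acid or an amine in place of the formyl group would hold the level of compound 3 (46.9%) in this series. Also open, on these data alone, is whether cyclohexyl on the aromatic nitrogen would leave the 4-formylphenyl result unchanged.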